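Swapping the aryl on the sulfonyl in an mGluR5 series

This account rests on a few compounds, and the source may have more. Where it says the series, first, only, none or still open, it means among the compounds named here.

Measured compounds:
- compound 1, `Cc1cc(C)cc(S(=O)(=O)c2cnc3cc(F)ccc3c2N2CCC(C)CC2)c1`: 80%
- compound 2, `Cc1ccc2ncc(S(=O)(=O)c3ccc(Cl)cc3)c(N3CCC(C)CC3)c2c1`: 79%

Two compounds have been run in an assay on isolated protein for displacement of a labelled ligand from metabotropic glutamate receptor 5 (Homo sapiens), with a stated time of 60 min, tested at 1 uM; on this read-out higher numbers stand for more inhibition at the one concentration tested (going by the name of the read-out) and lower numbers for less inhibition. In this assay compound 1 gives 80% and compound 2 gives 79%. Compound 2 lies within the usual scatter of compound 1, so the two values cannot be told apart, and the inhibition in this assay is level between them on this evidence.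

The next compound, compound 3 `CC1CCN(c2c(S(=O)(=O)c3cc(F)cc(F)c3)cnc3cc(F)ccc23)CC1`, has not yet been measured in this assay. It differs from compound 1 in one place: 3,5-difluorophenyl in place of 3,5-dimethylphenyl on a sulfonyl sulfur. Among the compounds with values here, no pair of measured compounds differs in just this way, so the data give no step of this kind to lean on.

Within the data shown here, with only two values in hand, and those two indistinguishable, the step is expected to stay within the scatter of this assay, in either direction; a modest move is expected, a number 8 percentage points lower from compound 1 to compound 3 (within the scatter). On that basis compound 3 is estimated to give 72% in this assay, most likely somewhere between 50% and 90%.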

Compound 3, a percentage reported as inhibition, at one concentration (the size of the read-out at that concentration, not a potency): 77%
The estimate for compound 3 lay 5 percentage points below the measured number; low and high end bracket the measured number.
By their numbers in this assay, from the lowest: compounds 3, 2 and 1 (each within the scatter of the next).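

In this assay, within the data shown here, putting 3,5-difluorophenyl in place of 3,5-dimethylphenyl on a sulfonyl sulfur gives a number 3 percentage points lower from compound 1 to compound 3 (within the scatter) and this is the only step in the set that isolates a single place, as compound 1 and compound 2 differ in more than one. It shows that, with the rest of compound 1 unchanged, this read-out does not separate the two aryl groups, which have the same count of heavy atoms but carry fluorine in one case and methyl in the other. No measurement at hand explains this outcome or ties it to any property of either group.

The compounds shown leave open how far this level reading extends on the sulfonyl sulfur, for example to an aryl carrying a carboxylic acid or an amine, or to a longer alkyl chain in place of the aryl. They also leave open whether compound 1 and compound 3 would remain level in a full potency measurement, as a reading at one concentration is not a potency.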